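The source may report more compounds than this note shows. Statements on the series, on what has been measured and on what is new or still open speak of the compounds shown alone.

In a functional assay on NCI-H2122 cells (Homo sapiens) for inhibition, read by microscopy, with a stated time of 10 days (a higher number here means a weaker inhibitor, a lower number a stronger inhibitor), compound 1 `Cc1nn(C)c2c1C(c1ccc(C(C)C)cc1)C(C#N)=C(N)O2` gives 4000 nM. Compound 2 `CC(C)c1ccc(C2C(C#N)=C(N)Oc3c2c(-c2ccccc2)nn3C)cc1` differs from it by phenyl in place of methyl on an aromatic carbon, and in this assay compound 2 gives 5400 nM; the step of a 1.4-fold higher number from compound 1 to compound 2 (0.13 log units; within the scatter). Compound 3 `Cc1nn(C)c2c1C(c1ccncc1)C(C#N)=C(N)O2` shares the core but differs from compound 1 in a larger part of the molecule, and the difference between the two cores is not broken down here. In this assay compound 3 gives 4100 nM, a value that sits within the scatter of compound 1 and also within the scatter of compound 2, so no order among the three can be read from these numbers. Compound 4 `Cn1nc(-c2ccccc2)c2c1OC(N)=C(C#N)C2c1ccncc1` differs from compound 3 by phenyl in place of methyl on an aromatic carbon, the same change, at the same place, as that from compound 1 to compound 2. Because the earlier step of a 1.4-fold higher number from compound 1 to compound 2 (0.13 log units; within the scatter) remained within the scatter, the step expected for compound 4 is a 1.3-fold higher number from compound 3 to compound 4 (0.13 log units; within the scatter). Compound 4 is therefore estimated at 5500 nM in this assay, with an expected range from 2800 nM to 11000 nM, pending the measurement.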

Compound 4, half-maximal inhibitory concentration: 5200 nM
Beside the measured number, compound 4's estimate is 1.1-fold (0.02 log units) above it, and the stated range covers the measured number.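

The new step in this assay, phenyl in place of methyl on an aromatic carbon, is a 1.3-fold higher number from compound 3 to compound 4 (0.10 log units; within the scatter), and the other new step, pyridin-4-yl in place of 4-isopropylphenyl on a saturated ring carbon, is a 1.0-fold lower number from compound 2 to compound 4 (0.02 log units; within the scatter). Set beside the earlier step, the phenyl change reads alike on the two cores: the same change on two cores in this assay, a 1.4-fold higher number (0.13 log units; within the scatter) from compound 1 to compound 2 and a 1.3-fold higher number (0.10 log units; within the scatter) from compound 3 to compound 4, 1.1-fold (0.03 log units) apart, within the scatter of two such steps. Within the data shown here, since each step lies within the scatter, this shows only that the change leaves no measurable mark on either core, so it does not show that a real effect of the change carries from one core to another, and it says nothing about any further core.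

The compounds shown leave open whether another group on that aromatic carbon, such as an amine or a longer chain, would give a step beyond the scatter. They also leave open whether a carboxylic acid on the ring of the group at the saturated ring carbon would do so.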